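Methoxy for cyclopentylamino on the aromatic carbon of compound 1

This account rests on a few compounds, and the source may have more. Where it says the series, first, only, none or still open, it means among the compounds named here.

Compound 1 `Fc1ccc(-c2nn3c(NC4CCCC4)cc(NC4CCCC4)cc3c2-c2ccnc(NC3CCCC3)n2)cc1` was run in an ADME assay on Vero cells (Chlorocebus sabaeus) for cytotoxicity; on this read-out lower numbers stand for higher toxicity in this test and higher numbers for lower toxicity in this test. In this assay compound 1 gives > 40000 nM, which is a limit of the assay and not a number. Compound 2 `CC(C)Sc1cc(NC2CCCC2)cc2c(-c3ccnc(NC4CCCC4)n3)c(-c3ccc(F)cc3)nn12` also sits at a limit in this assay, giving > 40000 nM. Compound 3 `COCCOc1cc(NC2CCCC2)cc2c(-c3ccnc(NC4CCCC4)n3)c(-c3ccc(F)cc3)nn12` gives 32500 nM in this assay. Because the limit of > 40000 nM in this assay, at which 2 of the 3 values shown sit, holds compound 1 and compound 2 alike, the step that the two limits leave unreadable from compound 1 to compound 2 cannot be sized. Compound 4 `COc1cc(NC2CCCC2)n2nc(-c3ccc(F)cc3)c(-c3ccnc(NC4CCCC4)n3)c2c1` differs from compound 1 by methoxy in place of cyclopentylamino on an aromatic carbon. The measured steps that bear on this change are an at least 1.2-fold lower number from compound 1 to compound 3 (0.09 log units; that floor lies within the scatter) and an at least 1.2-fold lower number from compound 2 to compound 3 (0.09 log units; that floor lies within the scatter), both placing 2-methoxyethoxy on that aromatic carbon, and both show only a floor that lies within the scatter. For compound 4 a step of comparable size, an at least 1.0-fold lower number from compound 1 to compound 4 (0.02 log units; that floor lies within the scatter), is therefore expected, nothing beyond the scatter. Compound 4 is estimated at 38000 nM, in the range 20000 nM to 80000 nM, with a fair chance that this assay again reports only a limit.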

Compound 4, half-maximal cytotoxic concentration: > 40000 nM
Compound 4: no number, only a limit (the forecaster's own chance of this, stated with the estimate: 50%); at least 1.0-fold (0.02 log units) between middle value and limit.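

Compound 1 and compound 4 both stand at a limit, so no step between them can be read, because neither gives a number: the limit of > 40000 nM in this assay, at which 3 of the 4 values shown sit.

The compounds shown leave open whether methoxy in place of cyclopentylamino on that aromatic carbon changes the read-out in this assay at all.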